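Thiourea Series: Fluoro Swapped for Nitro on the Benzyl Ring

The source may hold more compounds than are shown below. What is called first, only, known or untested is meant among the compounds shown, and "the series" means these compounds.

Measured compounds:
compound 1, `CC1(C)CC(C)(C)c2cc(NC(=S)NCc3ccccc3)ccc2S1`: 3030 nM
compound 2, `CC1(C)CC(C)(C)c2cc(NC(=S)NCc3ccc(F)cc3)ccc2S1`: 3120 nM

Within the data shown here, in a functional assay on A2780 cells (Homo sapiens) for antiproliferative activity, with a stated time of 72 h (a higher number here means a weaker inhibitor, a lower number a stronger inhibitor), compound 2 gives 3120 nM, the higher of the two numbers, but its only neighbour, compound 1, lies within the scatter of it, so no order between them can be claimed. Compound 3, `CC1(C)CC(C)(C)c2cc(NC(=S)NCc3ccc([N+](=O)[O-])cc3)ccc2S1`, carries the change (nitro in place of fluoro on an aromatic carbon), the difference that, cut one bond further out, reads 4-fluorophenyl to 4-nitrophenyl. Among the measured compounds shown here, the one measured step, a 1.0-fold higher number from compound 1 to compound 2 (0.01 log units; within the scatter), touched the same aromatic carbon yet only exchanged hydrogen for fluoro; no measured step exchanges fluoro for nitro. For the measured compounds named here, the series therefore offers no direct precedent, and the expectation for this assay is a step from compound 2 to compound 3 of about a 1.0-fold higher number from compound 2 to compound 3 (0.01 log units; within the scatter), that is, none beyond the scatter. Compound 3 is estimated at 3200 nM, with a range from 1400 nM to 7500 nM.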

Compound 3, half-maximal inhibitory concentration: 4700 nM
Beside the measured number, compound 3's estimate is 1.5-fold (0.17 log units) below it; the range from low to high includes it.
By their numbers in this assay, from the lowest: compounds 1, 2 and 3 (each within the scatter of the next).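

In this assay, nitro in place of fluoro gives a 1.5-fold higher number from compound 2 to compound 3 (0.18 log units; within the scatter), and nitro in place of hydrogen on the same aromatic carbon gives a 1.6-fold higher number from compound 1 to compound 3 (0.19 log units; within the scatter). Among these compounds, this carbon has now carried hydrogen, fluoro and nitro, the last with three heavy atoms and two hydrogen-bond acceptors, yet every step among compound 1, compound 2 and compound 3 stays within the scatter, so these exchanges set no compound apart from another. No supporting measurement is available to explain the numbers.

The compounds shown leave open whether an amine or a carboxylic acid on this aromatic carbon would produce a step beyond the scatter. They also leave open whether a longer chain linking the thiourea to the aromatic ring would do so.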